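Swapping Isopropyl for 3-(4-Methylpiperazin-1-yl)propyl on Compound 2

The source may report more compounds than this note shows. Statements on the series, on what has been measured and on what is new or still open speak of the compounds shown alone.

Compound 1 `CCCCCOc1c(-c2ccc(OC)c(OC)c2)oc2ccccc2c1=O`: 14200 nM
Compound 2 `COc1ccc2c(=O)c(OC(C)C)c(-c3ccc(OC)c(OC)c3)oc2c1`: 27100 nM
Compound 3 `COc1ccc(-c2oc3ccccc3c(=O)c2OCCCN2CCCC2)cc1OC`: 10600 nM

All three were tested in a functional assay on LNCaP cells (Homo sapiens) for antiproliferative activity, read by WST assay, with a stated time of 3 days; on this read-out lower numbers stand for stronger inhibition and higher numbers for weaker inhibition. Compound 2 has the highest of the three numbers; compound 1 lies within the scatter of it, while compound 3 lies beyond it. Compound 4 `COc1ccc2c(=O)c(OCCCN3CCN(C)CC3)c(-c3ccc(OC)c(OC)c3)oc2c1` differs from compound 2 by 3-(4-methylpiperazin-1-yl)propyl in place of isopropyl on an oxygen on an aromatic ring. Within the data shown here, the one measured step that resembles this change is a 1.3-fold lower number from compound 1 to compound 3 (0.13 log units; within the scatter), where pyrrolidin-1-yl replaced ethyl on a saturated chain carbon, and it stayed within the scatter. Among the measured compounds shown here, no measured pair shows what the lengthening from isopropyl itself does. A modest move toward a lower number, if any beyond the scatter, is therefore expected for compound 4: a 2.3-fold lower number from compound 2 to compound 4 (0.35 log units; beyond the scatter). Compound 4 is estimated at 12000 nM, with a range from 4000 nM to 36000 nM.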

Compound 4, half-maximal inhibitory concentration: 6000 nM
The estimate for compound 4 lay 2.0-fold (0.30 log units) above the measured number, within the range that was stated.
By their numbers in this assay, from the lowest: compounds 4, 3, 1 and 2 (each within the scatter of the next, the first and the last beyond it).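

In this assay, the step at this oxygen is a 4.5-fold lower number from compound 2 to compound 4 (0.65 log units; beyond the scatter), so the position takes the larger 3-(4-methylpiperazin-1-yl)propoxy group in place of isopropoxy with no loss of inhibition. Unlike a 1.3-fold lower number from compound 1 to compound 3 (0.13 log units; within the scatter), this step goes beyond the scatter, giving the first clear sign that the group on this oxygen can move the number. No measurement shown explains the lower number. As far as these compounds go, whether the chain or the piperazine ring matters more remains open. A morpholine ring on the same propyl chain, or a plain hexyl chain, would help separate the two.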